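Alkynyl phenylpropanoic acids: trimming the enyne terminus

A few compounds are considered here, and "the series" means these few. Any claim that something is new, unique, unknown or untested is made for them only; others in the source may bear on it.

Measured so far:
compound 1, `O=C(O)CCc1ccc(C#CC2(O)CCCCC2)cc1`: < 100000 nM
compound 2, `C/C=C(\C)C#Cc1ccc(CCC(=O)O)c(F)c1`: 37.2 nM
compound 3, `O=C(O)CCc1ccc(C#CC2=CCCCC2)cc1`: 200 nM

The series shares a phenylpropanoic acid core carrying an alkynyl substituent. In a functional assay on 1321-N1 cells for agonist activity at Free fatty acid receptor 1 (Homo sapiens), read by calcium flux, with a stated time of 0.4 s (on this read-out higher numbers stand for an effect only at larger amounts of compound and lower numbers for an effect already at smaller amounts), compound 2 gives 37.2 nM, the lowest of the two numbers in hand. Compound 3 gives 200 nM, a higher number than compound 2 by a margin beyond the scatter. Compound 1 gives only a limit, < 100000 nM, the value at which (the limit of < 100000 nM in this assay, at which 1 of the 3 values shown sits); it is not a number and is set aside for comparison.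

The next compound, compound 4, `C=C(C)C#Cc1ccc(CCC(=O)O)c(F)c1`, differs from compound 2 in one place: 1-methylethenyl in place of 1-methylprop-1-en-1-yl on a triple-bonded carbon. The carboxylic acid, the core and the fluorine are unchanged; the alkyne is kept, and only the terminal alkene loses one carbon of its chain. For the measured compounds named here, no pair among the measured compounds reproduces this step, so its size is not known from the data. The expectation rests on the closeness of the two structures: a small step, if any, probably toward a somewhat higher number in this assay, and quite possibly none beyond the scatter.

Compound 4 is therefore expected at 60 nM in this assay, within 20 nM to 200 nM. The step this estimate implies is a 1.6-fold higher number from compound 2 to compound 4 (0.21 log units; within the scatter).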

Compound 4, half-maximal effective concentration: 81.3 nM
Compound 4: the middle estimate sits 1.4-fold (0.13 log units) below what was measured; the range from low to high includes it.
By their numbers in this assay, from the lowest: compound 2; then compound 4; then compound 3.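

In this assay, for the compounds shown here, replacing 1-methylprop-1-en-1-yl with 1-methylethenyl on the triple-bonded carbon gives a 2.2-fold higher number from compound 2 to compound 4 (0.34 log units; beyond the scatter), the first single-change step and a modest one. This position is therefore sensitive to the size of the terminal alkenyl group even when the double bond, the alkyne, the fluorine and the carboxylic acid are all kept, although compound 4 still gives 81.3 nM with the shorter group. No measured property in hand bears on this step, so the data assign it no cause.

Going by these compounds, it remains open whether an isopropyl group, which has no double bond, or a longer chain such as 1-methylbut-1-en-1-yl at the same triple-bonded carbon would continue this trend or break it. The contribution of the fluorine also remains unresolved, since compound 3 differs from compound 2 in more than one place and that comparison cannot separate the fluorine from the terminal group.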